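The source may hold more compounds than are shown below. What is called first, only, known or untested is meant among the compounds shown, and "the series" means these compounds.

Working notes on the series. Compound 1 `Cc1ccc(/C=C(/C#N)C(=O)c2ccc[nH]2)cc1`, compound 2 `N#C/C(=C/c1ccc([N+](=O)[O-])cc1)C(=O)c1ccc[nH]1` and compound 3 `N#C/C(=C/c1ccc(O)cc1)C(=O)c1ccc[nH]1` differ in one group on an aromatic carbon. In a functional assay on MIA cells (Homo sapiens) for cytotoxicity, read by MTT assay, with a stated time of 72 h (on this read-out higher numbers stand for weaker inhibition of growth and lower numbers for stronger inhibition of growth), compound 1 gives 27000 nM. Compound 2 gives < 10000 nM, which is a limit of the assay. Compound 3 gives 11000 nM, the lower of the two exact numbers, and compound 1 is its nearest neighbour.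

The next structure is compound 4 `COc1ccc(/C=C(/C#N)C(=O)c2ccc[nH]2)cc1`. The change is methyl in place of hydrogen on an oxygen on an aromatic ring, hydroxy to methoxy. Within the data shown here, no measured step makes this change, so the evidence is indirect. The closest guide is a 2.5-fold lower number from compound 1 to compound 3 (0.39 log units; beyond the scatter), which is modest. The other steps are an at least 2.7-fold lower number from compound 1 to compound 2 (0.43 log units; beyond the scatter) and an at least 1.1-fold higher number from compound 2 to compound 3 (0.04 log units; that floor lies within the scatter), and the floor of the latter lies within the scatter.

With steps of this modest size as the guide, no step beyond the scatter is expected in this assay, with a slight lean towards a higher number. The expected step is a 1.4-fold higher number from compound 3 to compound 4 (0.13 log units; within the scatter). For compound 4 the estimated value is 15000 nM, with an expected range of 6000 nM to 35000 nM.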

Compound 4, concentration for 50% growth inhibition: < 10000 nM
Compound 4: a limit, no number; the forecaster's own chance of this, stated with the estimate: 15%; at least 1.5-fold (0.17 log units) between middle value and limit.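

Replacing the hydrogen on the oxygen with methyl does not raise the number in this assay: the step is an at least 1.1-fold lower number from compound 3 to compound 4 (0.04 log units; that floor lies within the scatter), so a free hydroxy is not shown to be needed here. Methoxy also separates from methyl at this aromatic carbon, with an at least 2.7-fold lower number from compound 1 to compound 4 (0.43 log units; beyond the scatter), which puts nitro, hydroxy and methoxy all on the lower side of compound 1. The step between compound 2 and compound 4 cannot be read, as both values are limits, and the series reaches the edge of what can be resolved here: the limit of < 10000 nM in this assay, at which 2 of the 4 values shown sit.

From the compounds shown here alone, how far compound 2 and compound 4 lie past that limit remains open, so no order among nitro, hydroxy and methoxy can be given. Also open, going by these compounds, is whether an amine or a carboxylic acid on the same aromatic carbon, or a longer chain on the oxygen in place of methyl, would shift the number in this assay beyond the scatter.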